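Urea-linked chloropyrazines against bladder cancer cells

This account rests on a few compounds, and the source may have more. Where it says the series, first, only, none or still open, it means among the compounds named here.

Measured so far:
Compound 1 `Cc1ccc(NC(=O)Nc2cccc(CNc3nccnc3Cl)c2)cc1`: 9820 nM
Compound 2 `O=C(Nc1cccc(CNc2nccnc2Cl)c1)Nc1ccccc1F`: 7450 nM

Both compounds were tested in a functional assay on T-24 cells (Homo sapiens) for antiproliferative activity, read by MTT assay, with a stated time of 48 h; a lower number here means a stronger inhibitor, a higher number a weaker inhibitor. Compound 1 gives 9820 nM, and compound 2 gives 7450 nM. Among the compounds with values here, the one step recorded between them, a 1.3-fold lower number from compound 1 to compound 2 (0.12 log units; within the scatter), is too small to count as a real change, so the two compounds sit together at the weak end of the scale. Compound 2 holds the lower of the two numbers, but by a margin inside the usual scatter, so it cannot be called the stronger inhibitor.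

The next compound, compound 3 `O=C(Nc1ccc(Cl)cc1)Nc1cccc(CNc2nccnc2Cl)c1`, is built from compound 2 by a single swap: 4-chlorophenyl in place of 2-fluorophenyl on an amide-type nitrogen. Within the data shown here, the only measured step that touches this part of the molecule is the one from compound 1 to compound 2, which itself stayed within the scatter, so the data give no basis to expect more than a small shift in this assay in either direction. Compound 3 is therefore estimated at 8000 nM, with a plausible range of 3000 nM to 20000 nM, which corresponds to an expected step of a 1.1-fold higher number from compound 2 to compound 3 (0.03 log units; within the scatter).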

Compound 3, half-maximal inhibitory concentration: 5470 nM
Compound 3: the middle estimate sits 1.5-fold (0.17 log units) above what was measured; measured number inside the range.
By their numbers in this assay, from the lowest: compounds 3, 2 and 1 (each within the scatter of the next).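

In this assay the amide-type nitrogen now carries a third aryl group, and 4-chlorophenyl in place of 2-fluorophenyl gives a 1.4-fold lower number from compound 2 to compound 3 (0.13 log units; within the scatter) while chloro in place of methyl on an aromatic carbon gives a 1.8-fold lower number from compound 1 to compound 3 (0.25 log units; within the scatter). The second of these steps is new in kind: it keeps the substituent on the same ring carbon and changes only the substituent, yet it stays inside the scatter just as the swap of 2-fluorophenyl for 4-chlorophenyl does. Compounds 1, 2 and 3 therefore cannot be ranked, and among these three phenyl groups neither the substituent nor its place on the ring has a measurable effect on the number, though no outside measurement bears on this result.

As far as these compounds go, all three compounds keep a substituted phenyl ring on this nitrogen, so it remains open whether a carboxylic acid, an amine or a longer alkyl chain there would move the number beyond the scatter. The compounds shown also share one unchanged core, which leaves open how much of the activity depends on this end of the molecule at all.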